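The compounds below may be only part of what the source reports. "The series", "measured", "known", "first", "only" and "open" are said of these compounds alone.

Measured in a physicochemical assay for solubility, with a stated time of 18 h, at pH 7.4; on this read-out lower numbers stand for lower solubility and higher numbers for higher solubility:
- compound 1 `COc1ccc(-c2ccc3c(NCCCNCc4cccc(OC)c4O)ccnc3c2)cc1`: 32000 nM
- compound 2 `FC(F)(F)c1ccc(-c2ccc3c(NCCCNCc4ccco4)ccnc3c2)cc1`: 32000 nM

Compound 1 stands level with compound 2 at 32000 nM, so the two cannot be ranked on this assay. Compound 3 `COc1cccc(CNCCCNc2ccnc3cc(Cc4cccc(C(F)(F)F)c4)ccc23)c1O` has not yet been measured. Relative to compound 1 it carries 3-(trifluoromethyl)benzyl in place of 4-methoxyphenyl on an aromatic carbon, with 3-(trifluoromethyl)benzyl in place of 4-methoxyphenyl on an aromatic carbon. Among the compounds with values here, no measured pair differs in one place, so nothing yet shows the size of such a step. Within the data shown here, the only guide is that two differing structures give one reading, with compound 1 at 32000 nM. A small downward change that stays within the scatter is therefore expected, and the estimated step is a 1.6-fold lower number from compound 1 to compound 3 (0.20 log units; within the scatter). For compound 3 the estimated value is 20000 nM, with an expected range from 6000 nM to 40000 nM.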

Compound 3, solubility: 4200 nM
The estimate for compound 3 lay 4.8-fold (0.68 log units) above the measured number; the measured number lies below the stated range.
By their numbers in this assay, from the lowest: compound 3; then compounds 1 and 2 (each within the scatter of the next).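

On an aromatic carbon of the shared core, para to a fused ring and meta to a fused ring, replacing 4-methoxyphenyl with 3-(trifluoromethyl)benzyl in this assay gives a 7.6-fold lower number from compound 1 to compound 3 (0.88 log units; beyond the scatter). Within the data shown here, this is the first single-place step, and it shows that the read-out can respond to a change at this position, which the level values of compound 1 and compound 2, differing in more than one place, could not show. No measurement at hand accounts for this step.

The step changes the ring substituent and the attachment to the core together, so their separate contributions remain unresolved; 4-methoxybenzyl or 3-(trifluoromethyl)phenyl at this carbon would divide them. On these data alone, how a carboxylic acid or an amine at this position would read also remains open.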